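One Change at the Carbonyl Carbon

The source may report more compounds than this note shows. Statements on the series, on what has been measured and on what is new or still open speak of the compounds shown alone.

Compound 1 `COc1cc(-c2nn(-c3cccc(NC(=O)c4ccc(Cl)c(C(F)(F)F)c4)c3)cc2-c2ccncc2)ccc1Cl` was examined in a functional assay on T47D cells (Homo sapiens) for inhibition, read by sulforhodamine B assay, with a stated time of 48 h; on this read-out higher numbers stand for weaker inhibition of growth and lower numbers for stronger inhibition of growth. In this assay compound 1 reaches only the limit > 32500 nM, which is a limit of the assay and not a number; its standing is the limit of > 32500 nM in this assay, at which 1 of the 2 values shown sits. Compound 2 `O=C(Nc1cccc(-n2cc(-c3ccncc3)c(-c3ccc(Cl)c(O)c3)n2)c1)Nc1cc(C(F)(F)F)cc(C(F)(F)F)c1` in this assay gives 14000 nM. Compound 3 `COc1cc(-c2nn(-c3cccc(NC(=O)Nc4cccc(C(F)(F)F)c4)c3)cc2-c2ccncc2)ccc1Cl` differs from compound 1 by (3-(trifluoromethyl)phenyl)amino in place of 4-chloro-3-(trifluoromethyl)phenyl on a carbonyl carbon. For the measured compounds named here, no measured step joins compound 1 and compound 3, so only an expectation can be given. Compound 3 is expected to show stronger inhibition than the limit, a step of an at least 2.1-fold lower number from compound 1 to compound 3 (0.33 log units; beyond the scatter) beyond the usual scatter. Compound 3 is estimated at 15000 nM, with a range from 5000 nM to 40000 nM.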

Compound 3, concentration for total growth inhibition: > 50000 nM
Compound 3 was reported as a limit (the forecaster's own chance of this, stated with the estimate: 35%); at least 3.3-fold (0.52 log units) between middle value and limit.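

In this assay compound 1 gives only the limit > 32500 nM. For the compounds shown here, compound 3 gives only the limit > 50000 nM, so no step from compound 1 to compound 3 can be read. From the compounds shown here alone, whether this change on the carbonyl carbon strengthens or weakens inhibition of growth stays open.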